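Swapping the Aryl Group at a Saturated Ring Carbon

The source may hold more compounds than are shown below. What is called first, only, known or untested is meant among the compounds shown, and "the series" means these compounds.

Of the compounds shown here, two built on the same core have so far been tested in a functional assay on OVCAR-4 cells (Homo sapiens) for antiproliferative activity, with a stated time of 48 h; a higher number here means that more compound is tolerated, a lower number that less compound is tolerated. Compound 1 `Cc1cc(O)c(C2=NN(c3ccc(S(N)(=O)=O)cc3)C(c3ccccc3Cl)C2)cc1Cl` gives 40000 nM in this assay. Compound 2 `Cc1cc(O)c(C2=NN(c3ccc(S(N)(=O)=O)cc3)C(/C=C/c3ccccc3)C2)cc1Cl` gives 48600 nM in this assay. Among the compounds with values here, compound 2 carries the higher of the two numbers, but its only neighbour, compound 1, lies close: a 1.2-fold higher number from compound 1 to compound 2 (0.08 log units; within the scatter). That step exchanged one group for another on a saturated ring carbon and left the read-out essentially where it was.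

Compound 3 `COc1ccc(C2CC(c3cc(Cl)c(C)cc3O)=NN2c2ccc(S(N)(=O)=O)cc2)cc1OC` has not yet been measured. It differs from compound 2 at that same saturated ring carbon: 3,4-dimethoxyphenyl in place of 2-phenylethenyl on a saturated ring carbon. Within the data shown here, the one measured step that bears on this change is the exchange at that position between compound 1 and compound 2, which stayed within the scatter. Among the measured compounds shown here, no other measured pair speaks to a dimethoxyphenyl group here. The expected step in this assay is therefore a 1.2-fold lower number from compound 2 to compound 3 (0.06 log units; within the scatter), nothing beyond the scatter. Compound 3 is estimated at 42000 nM, within a range from 15000 nM to 100000 nM.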

Compound 3, concentration lethal to 50% of the cells: > 100000 nM
Compound 3 ended at the assay's limit; the forecaster's own chance of this, stated with the estimate: 15%; at least 2.3-fold (0.37 log units) between middle value and limit.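

The saturated ring carbon is not indifferent to the group it carries: in this assay, 3,4-dimethoxyphenyl in place of 2-phenylethenyl gives an at least 2.0-fold higher number from compound 2 to compound 3 (0.31 log units; beyond the scatter), and 3,4-dimethoxyphenyl in place of 2-chlorophenyl gives an at least 2.5-fold higher number from compound 1 to compound 3 (0.39 log units; beyond the scatter). Both steps lie beyond the scatter, while the earlier exchange at this carbon stayed within it, so a change here can shift the read-out towards more compound being tolerated, and among the three groups shown, only 3,4-dimethoxyphenyl does this. Compound 3 stands at a limit of the assay rather than at an exact number, so both steps give only a minimum size and the full size remains unknown: the limit of > 100000 nM in this assay, at which 1 of the 3 values shown sits.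

The three compounds cannot separate the effect of the two methoxy groups from that of the rest of the entering group, and a phenyl group with a single methoxy group could help to make this separation. As far as these compounds go, it also remains open whether a smaller group such as methyl, or a group of another kind such as an amine or a carboxylic acid, would leave the number near those of compound 1 and compound 2 or move it to the limit.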